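A Small Swap on a Strong Inhibitor

The source may report more compounds than this note shows. Statements on the series, on what has been measured and on what is new or still open speak of the compounds shown alone.

Compound 1 `COc1cc(-c2ccnc3cc(-c4cn(CO)c5ccccc45)nn23)cc(OC)c1OC` and compound 2 `COc1cc(-c2ccnc3cc(-c4ccc(C)cc4)nn23)cc(OC)c1OC` share one core and differ in the group attached to it. In a functional assay on A549 cells (Homo sapiens) for inhibition, read by CCK-8 assay, with a stated time of 48 h (a lower number here means a stronger inhibitor, a higher number a weaker inhibitor), compound 1 gives 167 nM, while compound 2 gives 3 nM, the lower of the two numbers and so the stronger inhibitor; the gap between them lies well beyond the usual scatter of repeated measurements. Within the data shown here, no two measured compounds differ in a single place, so no single structural step has yet been tied to a shift in the numbers.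

Compound 3 `C=Cc1ccc(-c2cc3nccc(-c4cc(OC)c(OC)c(OC)c4)n3n2)cc1` has not been measured. It comes from compound 2 by one change: vinyl in place of methyl on an aromatic carbon. Among the measured compounds shown here, both groups are small, and nothing among the measured compounds shows how this particular swap moves the read-out. The change is therefore expected to be modest, in either direction or not beyond the scatter at all, and is estimated as a 1.3-fold higher number from compound 2 to compound 3 (0.12 log units; within the scatter). Compound 3 is accordingly expected to give about 4 nM in this assay, within a range from 1.5 nM to 12 nM.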

Compound 3, half-maximal inhibitory concentration: 1030 nM
The estimate for compound 3 lay 260-fold (2.41 log units) below the measured number, outside the stated range (above it).
By their numbers in this assay, from the lowest: compound 2; then compound 1; then compound 3.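

The size of this step shows that the group para to a large group on this aromatic ring is far from a place where small groups can be swapped freely. Vinyl in place of methyl gives a 340-fold higher number from compound 2 to compound 3 (2.54 log units; beyond the scatter) in this assay and is the only difference between the two structures. Neither group carries a ring, a net charge, a hydrogen-bond donor or a hydrogen-bond acceptor, so a one-place change that looks minor on paper can still move this read-out by a very large amount, and nothing measured here gives a reason for the jump.

What the compounds shown leave open is whether the double bond itself or simply the second carbon goes with the higher number, a question that an ethyl group, with the same two carbons and no double bond, could help to settle. Also open, going by these compounds, is how other small groups at this spot, such as a methoxy group, a chlorine atom or a plain hydrogen, would compare with methyl, and so whether methyl is unusually good here or vinyl is unusually poor.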